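The source may hold more compounds than are shown below. What is called first, only, known or untested is meant among the compounds shown, and "the series" means these compounds.

Measured so far in a functional assay on K562 cells (Homo sapiens) for cytotoxicity, read by MTT assay, with a stated time of 72 h; on this read-out lower numbers stand for stronger inhibition and higher numbers for weaker inhibition: compound 2 `COc1ccc(/C=C/C(=O)c2cc3ccc(OCc4cccc(OC)c4)cc3oc2=O)cc1`, > 100000 nM; compound 3 `COC(=O)c1ccc(/C=C/C(=O)c2cc3ccc(O)cc3oc2=O)cc1`, 4400 nM; compound 1 `COc1cccc(COc2ccc3cc(C(=O)/C=C/c4ccc(Cl)cc4Cl)c(=O)oc3c2)c1`, "not determined" (no result reported).

For compound 2 this assay reports only a limit, > 100000 nM, and no number. That limit, (the limit of > 100000 nM in this assay, at which 1 of the 3 values shown sits), is where one of the three entries sits. Compound 3 gives 4400 nM in this assay. Compound 1 has no result reported in this assay.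

Compound 4 `COc1cccc(COc2ccc3cc(C(=O)/C=C/c4c(Cl)cccc4Cl)c(=O)oc3c2)c1` differs from compound 2 in one place: 2,6-dichlorophenyl in place of 4-methoxyphenyl on a double-bonded chain carbon bound to a double-bonded chain carbon. Within the data shown here, no measured pair shows a change of this kind, so its size in this assay is open; a step toward stronger inhibition is expected, an at least 2.5-fold lower number from compound 2 to compound 4 (0.39 log units; beyond the scatter), with a real chance that only a limit is reported again. Compound 4 is estimated at 40000 nM, within a range from 6000 nM to 150000 nM.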

Compound 4, half-maximal inhibitory concentration: 15600 nM
Compound 4: the middle estimate sits 2.6-fold (0.41 log units) above what was measured; low and high end bracket the measured number.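

In this assay, with the rest of the molecule unchanged, 2,6-dichlorophenyl in place of 4-methoxyphenyl on a double-bonded chain carbon gives an at least 6.4-fold lower number from compound 2 to compound 4 (0.80 log units; beyond the scatter). This shows that the group at this position can change the read-out. The true size of the step remains unknown because compound 2 has only a limit, so the step is a minimum: the limit of > 100000 nM in this assay, at which 1 of the 4 values shown sits.

From the compounds shown here alone, whether the two chlorines are both needed remains open, since a single chlorine does not appear here. Also open, going by these compounds, is how a phenyl ring carrying an amine or a carboxylic acid would behave at this position.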